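Thiophene for Pyridine on a Hydroxyphenyl Pyridine Core

The source may report more compounds than this note shows. Statements on the series, on what has been measured and on what is new or still open speak of the compounds shown alone.

Compound 2 `Oc1ccc(-c2cc(-c3ccncc3)nc(-c3ccc(Cl)cc3)c2)cc1` has no number in an ADME assay on HEK293 cells (Homo sapiens) for cytotoxicity, read by CCK-8 assay and cell counting, with a stated time of 2 days; a lower number here means a stronger inhibitor, a higher number a weaker inhibitor: its result there is recorded as "not determined" (no result reported). Its nearest measured relatives are compound 1 `Oc1cccc(-c2cc(-c3ccc(Cl)cc3)nc(-c3cccs3)c2)c1`, which in this assay gives 11800 nM, and compound 3 `Oc1cccc(-c2cc(-c3ccncc3)nc(-c3ccc(Cl)cc3)c2)c1`, which in this assay gives 2890 nM. Compound 4 `Oc1ccc(-c2cc(-c3ccc(Cl)cc3)nc(-c3cccs3)c2)cc1` is obtained from compound 2 by one change: thiophen-2-yl in place of pyridin-4-yl on an aromatic carbon. Among the measured compounds shown here, the only measured step that bears on this change runs the other way, a 4.1-fold lower number from compound 1 to compound 3 (0.61 log units; beyond the scatter), so the reverse exchange would be expected to push the number upward in this assay by a step of roughly that size, toward a weaker inhibitor. Since compound 2 has no number of its own, the estimate must instead rest on compound 1, which carries the same thiophen-2-yl group and in this assay gives 11800 nM. Compound 4 is therefore expected to show a half-maximal inhibitory concentration near 12000 nM, within a range of 4000 nM to 40000 nM.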

Compound 4, half-maximal inhibitory concentration: 4520 nM
Compound 4: middle estimate off by 2.7-fold (0.42 log units), on the high side; low and high end bracket the measured number.
By their numbers in this assay, from the lowest: compounds 3 and 4 (each within the scatter of the next); then compound 1.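

With the thiophen-2-yl group held constant, the result shows that the place of the hydroxyl group on the phenyl ring also matters in this assay: 4-hydroxyphenyl in place of 3-hydroxyphenyl gives a 2.6-fold lower number from compound 1 to compound 4 (0.42 log units; beyond the scatter). Among the compounds shown here, the earlier compounds showed only a change of the thiophen-2-yl group, so this is the first step in which that group stays fixed and the hydroxyphenyl group changes. Nothing shown here gives a measured reason for this step.

Compound 2 has no number, so the exchange between pyridin-4-yl and thiophen-2-yl cannot be read with the 4-hydroxyphenyl group in place, nor can the hydroxyl shift be read with pyridin-4-yl present. Also open, as far as these compounds go, is how an amine or a carboxylic acid in place of the hydroxyl group would read in this assay.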